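This account rests on a few compounds, and the source may have more. Where it says the series, first, only, none or still open, it means among the compounds named here.

Compound 1 `CC1CC/C(=N\Nc2ccccc2F)c2ncc(C(=O)O)c(=O)n21`: > 1000 umol/kg
Compound 2 `CC1CC/C(=N\Nc2ccc(F)cc2)c2ncc(C(=O)O)c(=O)n21`: > 1000 umol/kg
Compound 3 `CC1CC/C(=N\Nc2ccccc2Cl)c2ncc(C(=O)O)c(=O)n21`: > 1000 umol/kg

All three values in a functional assay on the whole organism for inhibition, with Rattus norvegicus as the target (on this read-out lower numbers stand for an effect already at smaller amounts and higher numbers for an effect only at larger amounts of compound), are limits of the assay and not numbers, as the limit of > 1000 umol/kg in this assay, at which 3 of the 3 values shown sit, records. The steps between them, a step that the two limits leave unreadable from compound 1 to compound 2, a step that the two limits leave unreadable from compound 1 to compound 3 and a step that the two limits leave unreadable from compound 2 to compound 3, therefore cannot be read for size or direction. Compound 3 thus sits at the limit alongside the other two, and no difference within the series is resolved.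

The next compound, compound 4 `CC1CC/C(=N\Nc2cccc(Cl)c2)c2ncc(C(=O)O)c(=O)n21`, differs from compound 3 only in the aryl attached to the amine nitrogen: 3-chlorophenyl in place of 2-chlorophenyl on an amine nitrogen. Within the data shown here, no measured step involving any change on that aryl has yielded a readable size, so nothing supports expecting an effect within the range of the assay. The expectation for compound 4 is that it most likely again returns a limit, and the expected step that the limit leaves unreadable from compound 3 to compound 4 is set to lie within the scatter. Compound 4 is estimated at 1500 umol/kg, in the range 300 umol/kg to 6000 umol/kg.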

Compound 4, dose for 50% inhibition: > 100 umol/kg
Compound 4 ended at the assay's limit; the forecaster's own chance of this, stated with the estimate: 85%; the middle value is on the limit's open side.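

In this assay compound 4 gives > 100 umol/kg, which is a limit of the assay and not a number. The steps from compound 1, compound 2 and compound 3 to compound 4 therefore cannot be read. The compounds shown leave open whether any of these aryl groups on the amine nitrogen gives a measurable effect in this assay.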